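The source may hold more compounds than are shown below. What is called first, only, known or untested is meant among the compounds shown, and "the series" means these compounds.

Of the compounds shown here, three sharing one core have been measured in a functional assay on MKN-45 cells (Homo sapiens) for cytotoxicity, read by MTT assay, with a stated time of 72 h; a lower number here means a stronger inhibitor, a higher number a weaker inhibitor. Compound 1 `COc1cc2c(Oc3ccc(NC(=O)c4nn(-c5ccccc5F)c(=O)c5ccccc45)cc3F)ccnc2cc1OCCCN1CCCC1` gives 140 nM. Compound 2 `COc1cc2c(Oc3ccc(NC(=O)c4nn(-c5ccccc5)c(=O)c5ccccc45)cc3F)ccnc2cc1OCCCN1CCC(C)CC1` gives 580 nM, and compound 3 `COc1cc2c(Oc3ccc(NC(=O)c4nn(-c5ccc(F)cc5)c(=O)c5ccccc45)cc3F)ccnc2cc1OCCCN1CCC(C)CC1` gives 130 nM. Among these three numbers compound 3 has the lowest, but its value and that of compound 1 lie within the usual scatter of each other, so neither can be set above the other. Among the compounds with values here, compound 2 stands apart, and the single change a 4.5-fold lower number from compound 2 to compound 3 (0.65 log units; beyond the scatter).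

Compound 4 `COc1cc2c(Oc3ccc(NC(=O)c4nn(-c5ccccc5F)c(=O)c5ccccc45)cc3F)ccnc2cc1OCCCN1CCC(C)CC1` is the next step. It differs from compound 3 by 2-fluorophenyl in place of 4-fluorophenyl on an aromatic nitrogen, so the fluorine on the phenyl ring moves while the rest of the molecule stays. Within the data shown here, no measured pair shows this move on its own. What the numbers do show is that compound 1, which carries a 2-fluorophenyl, and compound 3, which carries a 4-fluorophenyl, give values within the scatter of each other, although those two also differ elsewhere in the molecule. Among the measured compounds shown here, the one step that was measured concerned hydrogen against fluorine, not the position of the fluorine. The expectation is therefore a change no larger than the scatter, a 1.2-fold higher number from compound 3 to compound 4 (0.06 log units; within the scatter). Compound 4 is estimated at 150 nM, with a likely range from 70 nM to 350 nM.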

Compound 4, half-maximal inhibitory concentration: 260 nM
Beside the measured number, compound 4's estimate is 1.7-fold (0.24 log units) below it; the range from low to high includes it.
By their numbers in this assay, from the lowest: compounds 3, 1 and 4 (each within the scatter of the next); then compound 2.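

In this assay, moving the fluorine on the phenyl ring from the 4-fluorophenyl to the 2-fluorophenyl arrangement gives a step that stays within the scatter (a 2.0-fold higher number from compound 3 to compound 4 (0.30 log units; within the scatter)), so these two placements cannot be told apart in this series. The 2-fluorophenyl group also gives a lower number than the unsubstituted phenyl ring (a 2.2-fold lower number from compound 2 to compound 4 (0.35 log units; beyond the scatter)), which means the gain seen earlier with 4-fluorophenyl (a 4.5-fold lower number from compound 2 to compound 3 (0.65 log units; beyond the scatter)) is not confined to that one placement, although only these compounds show it. Within the data shown here, the new compound also gives the only direct comparison at the other end of the molecule, where 4-methylpiperidin-1-yl in place of pyrrolidin-1-yl on the chain leaves the number within the scatter (a 1.9-fold higher number from compound 1 to compound 4 (0.27 log units; within the scatter)).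

The compounds shown leave open how 3-fluorophenyl, or a phenyl ring carrying chlorine or a methoxy group, would compare, and whether a morpholine at the end of the chain would also stay within the scatter. No independent measurement is available to explain any of these steps.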